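A few compounds are considered here, and "the series" means these few. Any claim that something is new, unique, unknown or untested is made for them only; others in the source may bear on it.

Compound 1 `COC(=O)N[C@H](C(=O)NN(CCC[C@@](O)(Cc1ccccc1)C(=O)N[C@H]1c2ccccc2C[C@H]1O)Cc1ccc(F)cc1)C(C)(C)C` in an ADME assay on MT4 cells (Homo sapiens) for cytotoxicity; on this read-out lower numbers stand for higher toxicity in this test and higher numbers for lower toxicity in this test: > 10000 nM.
Compound 2 `COC(=O)N[C@H](C(=O)NN(CCC[C@@](O)(Cc1ccccc1)C(=O)N[C@H]1c2ccccc2C[C@H]1O)Cc1ccc(-c2ccccn2)cc1)C(C)(C)C`: > 10000 nM.
Compound 3 `COC(=O)N[C@H](C(=O)NN(CCC[C@@](O)(Cc1ccccc1)C(=O)N[C@H]1c2ccccc2C[C@H]1O)Cc1ccc(-c2noc(C)n2)cc1)C(C)(C)C`: > 10000 nM.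

The value of compound 1 in this assay is a limit of the assay, not a number. The same holds for compound 2, whose value is a limit. The value of compound 3 is a limit as well. Compound 1 therefore stands only at a limit in this assay, and no numbers exist against which its position could be ranked.

Compound 4 `COC(=O)N[C@H](C(=O)NN(CCC[C@@](O)(Cc1ccccc1)C(=O)N[C@H]1c2ccccc2C[C@H]1O)Cc1ccc(-c2nccs2)cc1)C(C)(C)C` differs from compound 1 in one place: 1,3-thiazol-2-yl in place of fluoro on an aromatic carbon. The measured steps that bear on this change replace the same fluoro on the same aromatic carbon with another aromatic group: a step that the two limits leave unreadable from compound 1 to compound 2 and a step that the two limits leave unreadable from compound 1 to compound 3. Neither step has a readable size, because of the limit of > 10000 nM in this assay, at which 3 of the 3 values shown sit. Beyond this the data give no foothold.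

With two aromatic groups at this place leaving the limit untouched, no step beyond the scatter is expected from compound 1 to compound 4, and the estimated step is a step that the limit leaves unreadable from compound 1 to compound 4. Compound 4 is therefore estimated at 20000 nM in this assay, within a range from 8000 nM to 60000 nM, with the outcome most likely reported again as a limit.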

Compound 4, half-maximal cytotoxic concentration: > 10000 nM
Compound 4 ended at the assay's limit; the forecaster's own chance of this, stated with the estimate: 85%; the middle value does not contradict the limit.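

No new step can be read between compound 4 and compound 1, compound 2 or compound 3, because each pair rests on limits rather than numbers: the limit of > 10000 nM in this assay, at which 4 of the 4 values shown sit. The compounds shown leave open how these four compounds rank in this assay, and whether exchanging the group at this place changes the read-out at all.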